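This account rests on a few compounds, and the source may have more. Where it says the series, first, only, none or still open, it means among the compounds named here.

Compounds measured in an ADME assay on SH-SY5Y cells (Homo sapiens) for cytotoxicity, read by MTT assay, with a stated time of 48 h; a higher number here means a weaker inhibitor, a lower number a stronger inhibitor:

Compound 1, `CCCCCCCCCCCCNC(=O)c1ccc(/C=C/C(=O)c2ccc(OC)cc2O)cc1`, gives > 100000 nM, which is a limit of the assay and not a number.
Compound 2, `CCCNC(=O)c1ccc(/C=C/C(=O)c2ccc(OC)cc2O)cc1`, gives > 100000 nM, again a limit of the assay.
Compound 3, `CCOCCOc1ccc(/C=C/C(=O)c2ccc(OC)cc2O)cc1`, gives > 100000 nM, also a limit of the assay.

Compound 2 thus stands only at a limit in this assay, as do the other two measured compounds, all three sitting at the limit of > 100000 nM in this assay, at which 3 of the 3 values shown sit. The step from compound 2 to the unmeasured compound 4, `COc1ccc(C(=O)/C=C/c2ccc(C(=O)Nc3ccc(C)cc3C)cc2)c(O)c1`, is the change (2,4-dimethylphenyl in place of propyl on an amide-type nitrogen). For the measured compounds named here, two measured steps touch compound 2: the step that the two limits leave unreadable from compound 1 to compound 2 and the step that the two limits leave unreadable from compound 2 to compound 3. Both are unreadable, since each joins two limits, so neither gives a direction or a size to carry over to compound 4. With all three measured values resting at the same limit, the expected step of a number no higher from compound 2 to compound 4 (the limit leaves the size open) is simply none that can be read beyond the scatter. For compound 4 the estimate in this assay is therefore 100000 nM, with a range from 30000 nM to 300000 nM, and most likely the assay will again report only a limit.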

Compound 4, half-maximal inhibitory concentration: > 100000 nM
Compound 4 ended at the assay's limit; the forecaster's own chance of this, stated with the estimate: 80%; the middle value sits exactly at the limit.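

The step from compound 2 to compound 4 cannot be read, and neither can any other step among compounds 1 to 4, since each joins two limits in this assay: the limit of > 100000 nM in this assay, at which 4 of the 4 values shown sit.

The compounds shown leave open whether 2,4-dimethylphenyl and propyl on the amide-type nitrogen differ at all in this read-out, since none of them gives an actual number.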